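The source may report more compounds than this note shows. Statements on the series, on what has been measured and on what is new or still open speak of the compounds shown alone.

Compound 1 `COc1cccc2c1CCC2c1ncc[nH]1` is the stronger of the two compounds already measured: in a functional assay on CHO cells for agonist activity at Alpha-1A adrenergic receptor (Homo sapiens), read by FLIPR and calcium flux (a lower number here means that less compound is needed, a higher number that more compound is needed for the effect), compound 1 gives 32 nM, while compound 2 `c1cc(-c2nccs2)c2c(c1)C(c1ncc[nH]1)CC2` gives 426 nM. Within the data shown here, the one recorded step, a 13-fold higher number from compound 1 to compound 2 (1.12 log units; beyond the scatter), shows how much the number moves when the methoxy group is exchanged for a larger ring. Compound 3 `COc1c(Cl)ccc2c1CCC2c1ncc[nH]1` keeps the methoxy group of compound 1 and differs only by chloro in place of hydrogen on an aromatic carbon. Among the measured compounds shown here, no measured step covers the addition of a chloro group at this position, and the thiazolyl step concerns a different site, so it offers little guidance beyond showing that the core tolerates change on that ring. Compound 3 is therefore expected to sit close to compound 1, with a step of a 1.1-fold lower number from compound 1 to compound 3 (0.03 log units; within the scatter) that stays within the usual scatter. For compound 3 the estimate in this assay is 30 nM, with a range from 8 nM to 120 nM.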

Compound 3, half-maximal effective concentration: 451 nM
Compound 3: middle estimate off by 15-fold (1.18 log units), on the low side, outside the stated range (above it).
By their numbers in this assay, from the lowest: compound 1; then compounds 2 and 3 (each within the scatter of the next).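

In this assay, placing a single chloro group on the aromatic carbon ortho to the methoxy group gives a 14-fold higher number from compound 1 to compound 3 (1.15 log units; beyond the scatter), a large step for a change of one heavy atom. This shows that the position is not indifferent to substitution, even with the methoxy group of compound 1 and the rest of the shared core left unchanged. Nothing available explains why the number moves with this change.

The compounds shown leave open whether this step belongs to chloro alone or would also follow from another group on the same carbon, such as fluoro, methyl or an amine. They also leave open whether chloro at this position would have the same effect with a group other than methoxy beside it in the series, such as ethoxy or a hydroxyl.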